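Cytotoxicity notes on the shared core: aryl swap

A few compounds are considered here, and "the series" means these few. Any claim that something is new, unique, unknown or untested is made for them only; others in the source may bear on it.

Compound 1 `CN(C)CCCCOC(=O)Nc1ccc(Cn2nc(-c3cccnc3)c3ccccc3c2=O)cc1` gives 68000 nM in an ADME assay on Huh-7 cells (Homo sapiens) for cytotoxicity, read by MTT assay, with a stated time of 48 h; a lower number here means that less compound is tolerated, a higher number that more compound is tolerated.
Compound 2 `CN(C)CCCCOC(=O)Nc1ccc(Cn2nc(-c3cnn(C)c3)c3ccccc3c2=O)cc1` gives 55900 nM in this assay.
Compound 3 `COc1ccc(-c2nn(Cc3ccc(NC(=O)OCCCCN(C)C)cc3)c(=O)c3ccccc23)cc1` gives 20300 nM in this assay.

Compound 3 carries the lowest number of the three. The steps into it are a 3.3-fold lower number from compound 1 to compound 3 (0.53 log units; beyond the scatter) and a 2.8-fold lower number from compound 2 to compound 3 (0.44 log units; beyond the scatter), both beyond the scatter, while a 1.2-fold lower number from compound 1 to compound 2 (0.09 log units; within the scatter) lies within it.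

Compound 4 `CN(C)CCCCOC(=O)Nc1ccc(Cn2nc(-c3cccc(F)c3)c3ccccc3c2=O)cc1` differs from compound 3 by 3-fluorophenyl in place of 4-methoxyphenyl on an aromatic carbon. Among the compounds with values here, no measured step exchanges one group on a six-membered aromatic ring of carbon only for another; the two steps in which 4-methoxyphenyl entered are the only ones that touch this position, and each was modest. The change from 4-methoxyphenyl to 3-fluorophenyl keeps a carbon-only aromatic ring in place, so the number for compound 4 is expected to stay close to that of compound 3, with the remaining uncertainty leaning toward a somewhat higher number.

Compound 4 is therefore expected at 26000 nM in this assay, within 11000 nM to 60000 nM.

The expected step is a 1.3-fold higher number from compound 3 to compound 4 (0.11 log units; within the scatter), no more than the usual scatter.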

Compound 4, half-maximal cytotoxic concentration: 37400 nM
Beside the measured number, compound 4's estimate is 1.4-fold (0.16 log units) below it, within the range that was stated.
By their numbers in this assay, from the lowest: compounds 3, 4, 2 and 1 (each within the scatter of the next, the first and the last beyond it).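

In this assay, within the data shown here, a 1.8-fold higher number from compound 3 to compound 4 (0.27 log units; within the scatter) is the first exchange at this aromatic carbon between two carbon-only aromatic rings, and it stays within the scatter, so 3-fluorophenyl and 4-methoxyphenyl are not separated here. Compound 4 also stays within the scatter of the two heteroaromatic compounds, with a 1.5-fold lower number from compound 2 to compound 4 (0.17 log units; within the scatter) and a 1.8-fold lower number from compound 1 to compound 4 (0.26 log units; within the scatter) both printed as within it, whereas compound 3 lies beyond the scatter of each, so a carbon-only aromatic ring at this position does not by itself set a compound apart from them. Nothing available speaks to the reason for these numbers.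

Open, going by these compounds, is how a carboxylic acid or an amine on this aromatic carbon would read in this assay. Also open, on these data alone, is whether a longer chain at this position would stay within the same narrow span of numbers.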